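The source may hold more compounds than are shown below. What is called first, only, known or untested is meant among the compounds shown, and "the series" means these compounds.

Three compounds have numbers in a functional assay on the whole organism (stomach) with Rattus norvegicus as the target; on this read-out higher numbers stand for an effect only at larger amounts of compound and lower numbers for an effect already at smaller amounts. Compound 1 `CCCc1ccc(C(=O)Nc2cc(C(=O)O)cc(C(=O)O)c2)cc1` gives 94.2 mg/kg in this assay. Compound 3 `COc1ccc(C(=O)Nc2cc(C(=O)O)cc(C(=O)O)c2)cc1OC` gives 116 mg/kg, within the scatter of compound 1, and compound 2 `NC(=O)c1ccc(NC(=O)c2ccc(-c3nn[nH]n3)cc2)cc1` gives 33 mg/kg, beyond the scatter and on the side of smaller amounts. Compound 1 therefore lies close to compound 3 and apart from compound 2. Compound 4 `O=C(O)c1ccc(C(=O)Nc2cc(C(=O)O)cc(C(=O)O)c2)cc1` is not yet measured; it differs from compound 1 by carboxy in place of propyl on an aromatic carbon. For the measured compounds named here, no measured pair shows what this change does; the only close comparison, compound 3 against compound 1, shows two differently substituted compounds staying within the scatter. A step from compound 1 to compound 4 of a 1.0-fold lower number from compound 1 to compound 4 (0.02 log units; within the scatter) is expected, none beyond the scatter. Compound 4 is estimated at 90 mg/kg in this assay, with a range from 35 mg/kg to 230 mg/kg.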

Compound 4, dose for 50% inhibition: 32.2 mg/kg
Compound 4: middle estimate off by 2.8-fold (0.45 log units), on the high side; the whole stated range lies above it.
By their numbers in this assay, from the lowest: compounds 4 and 2 (each within the scatter of the next); then compounds 1 and 3 (each within the scatter of the next).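

Read in this assay the exchange of propyl for carboxy on an aromatic carbon, para to a large group, gives a 2.9-fold lower number from compound 1 to compound 4 (0.47 log units; beyond the scatter) and thus shows that this position responds to what it carries, which no earlier pair could show. No evidence on the origin of this step is available. From the compounds shown here alone, whether the step follows from the incoming carboxy group or from the loss of propyl stays open. An amine, a methyl group or a longer chain at this position would help to separate the two.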